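The source may report more compounds than this note shows. Statements on the series, on what has been measured and on what is new or still open speak of the compounds shown alone.

Compounds measured in a functional assay on L1210 cells (Mus musculus) for inhibition; on this read-out lower numbers stand for stronger inhibition and higher numbers for weaker inhibition:
- Compound 1 `O=C1/C(=C/c2cccc(Cl)c2)Cc2ccccc21`: 41200 nM
- Compound 2 `O=C1/C(=C/c2ccc(Br)cc2)CCCc2ccccc21`: 50900 nM

Compound 2 gives 50900 nM and stands within the usual scatter of compound 1 at 41200 nM, so these two numbers cannot be told apart. Their structures differ in more than one place, so this pair does not show what any single change does.

Compound 3 `CN(C)c1ccc(/C=C2\CCCc3ccccc3C2=O)cc1` keeps the core of compound 2 and makes one change: dimethylamino in place of bromo on an aromatic carbon, para to a large group (dimethylamino in place of bromo on an aromatic carbon). Among the compounds with values here, no measured pair shows a single change of this kind, so the size of this step in this assay cannot be read from the data. Within the data shown here, the only guide is the closeness of the two known values, which suggests no step beyond the scatter and no firm direction. The expected step is a 1.5-fold lower number from compound 2 to compound 3 (0.16 log units; within the scatter), and the wide range below reflects how little evidence there is. For compound 3 the estimated value is 35000 nM, with an expected range from 12000 nM to 100000 nM.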

Compound 3, half-maximal inhibitory concentration: 1870 nM
For compound 3 the middle estimate is 19-fold (1.27 log units) above the measured one, and the stated range ends above it.
By their numbers in this assay, from the lowest: compound 3; then compounds 1 and 2 (each within the scatter of the next).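

Swapping bromo for dimethylamino on an aromatic carbon, para to a large group, gives in this assay a 27-fold lower number from compound 2 to compound 3 (1.43 log units; beyond the scatter) and so moves the value far beyond the scatter. Compounds 1 and 2 differ in more than one place and could not be told apart, so they gave no sign that the read-out could respond this strongly; this single change shows that the group at this position can matter a great deal. Dimethylamino differs from bromo in its size and atoms and carries a hydrogen-bond acceptor, but no measurement here links the step to any of these differences or gives a reason for it.

Going by these compounds, this is a single replacement at a single position, so it remains open whether a plain amino group, diethylamino or methoxy in the same place would give a similar step, or whether the effect belongs to dimethylamino alone. On these data alone, it is also open whether the same swap would have a step of similar size on the core of compound 1.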